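Aryl swap on the hydrazone carbon of a shared core

A few compounds are considered here, and "the series" means these few. Any claim that something is new, unique, unknown or untested is made for them only; others in the source may bear on it.

Two compounds of this series carry a measurement so far. Compound 1 `O=C(CSc1nnc(-c2ccncc2)o1)N/N=C/c1ccc(O)cc1` gives 7940 nM in a functional assay on BGC-823 cells (Homo sapiens) for cytotoxicity, read by MTT assay, with a stated time of 48 h; a higher number here means a weaker inhibitor, a lower number a stronger inhibitor. Compound 2 `COc1cccc(/C=N/NC(=O)CSc2nnc(-c3ccncc3)o2)c1` gives 15800 nM in this assay. Compound 2 thus holds the highest of the two numbers, and its nearest neighbour is compound 1, though the two differ only by a 2.0-fold higher number from compound 1 to compound 2 (0.30 log units; within the scatter).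

Compound 3 `O=C(CSc1nnc(-c2ccncc2)o1)N/N=C/c1ccccc1[N+](=O)[O-]` is the next member and has not yet been measured. It differs from compound 2 in one place: 2-nitrophenyl in place of 3-methoxyphenyl on a carbon with a double bond to nitrogen.

Within the data shown here, the only measured step that bears on this change is the one from compound 1 to compound 2, which is likewise an exchange of the aryl group on the carbon double-bonded to nitrogen, and that step stayed within the scatter. On that basis no step beyond the scatter is expected for the present exchange either, and compound 3 is expected to give about 13000 nM in this assay, within a range of 4000 nM to 45000 nM. The step this means, from compound 2 to compound 3, is estimated as a 1.2-fold lower number from compound 2 to compound 3 (0.08 log units; within the scatter).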

Compound 3, half-maximal inhibitory concentration: 41600 nM
For compound 3 the middle estimate is 3.2-fold (0.51 log units) below the measured one; low and high end bracket the measured number.
By their numbers in this assay, from the lowest: compounds 1 and 2 (each within the scatter of the next); then compound 3.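

In this assay the aryl group on the carbon with a double bond to nitrogen can move the number beyond the scatter: 2-nitrophenyl in place of 3-methoxyphenyl gives (a 2.6-fold higher number from compound 2 to compound 3 (0.42 log units; beyond the scatter)) and 2-nitrophenyl in place of 4-hydroxyphenyl gives (a 5.2-fold higher number from compound 1 to compound 3 (0.72 log units; beyond the scatter)), both modest, whereas the exchange between the two earlier aryl groups gave only (a 2.0-fold higher number from compound 1 to compound 2 (0.30 log units; within the scatter)). This position is therefore not indifferent to the aryl group, with compound 3 standing apart from compound 1 and compound 2, which remain within the scatter of each other and cannot be ordered. No measurement bearing on the origin of this step is available.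

Three aryl groups cannot separate the effect of the nitro group itself from the effect of where it sits on the phenyl ring, as the 2-nitrophenyl group differs from both others in identity and in placement at once. Also open, from the compounds shown here alone, is how an aminophenyl group or a carboxylic acid on the phenyl ring would read at this position on the shared core.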